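The source may hold more compounds than are shown below. What is called first, only, known or untested is meant among the compounds shown, and "the series" means these compounds.

Measured compounds:
compound 1 `O=C(/C=C\Nc1ccc(F)cc1)c1nc(-c2ccc(C(F)(F)F)cc2)n2ccccc12`: > 30000 nM
compound 2 `COc1ccc(-c2nc(C(=O)/C=C\Nc3ccc(F)cc3)c3ccccn23)cc1`: > 30000 nM
compound 3 `Cc1cc2cc(N/C=C\C(=O)c3nc(-c4ccc(F)cc4)n4ccccc34)ccc2[nH]1`: > 30000 nM

In a functional assay on B16-F10 cells (Mus musculus) for cytotoxicity, read by MTT assay, with a stated time of 48 h (a higher number here means a weaker inhibitor, a lower number a stronger inhibitor), compound 1 gives only a limit of the assay, > 30000 nM. Compound 2 likewise gives only a limit, > 30000 nM. Compound 3 also gives only a limit, > 30000 nM. The step that the two limits leave unreadable from compound 1 to compound 2 is therefore not readable. Compound 1 stands at the limit of > 30000 nM in this assay, at which 3 of the 3 values shown sit, as do the other two values shown. Compound 4 `O=C(/C=C\Nc1ccc(Cl)cc1)c1nc(-c2ccc(C(F)(F)F)cc2)n2ccccc12` differs from compound 1 by chloro in place of fluoro on an aromatic carbon. No measured step bears on this change: the single step shown is unreadable and every value sits at the limit. No shift beyond the scatter is expected, and a limit is again the most likely outcome. Compound 4 is estimated at 40000 nM, between 15000 nM and 150000 nM. The expected step is then a step that the limit leaves unreadable from compound 1 to compound 4.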

Compound 4, half-maximal inhibitory concentration: > 30000 nM
Compound 4 gave a limit, no number; the forecaster's own chance of this, stated with the estimate: 80%; the middle value does not contradict the limit.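

Compound 1 and compound 4 both give only a limit, so no size can be read for chloro in place of fluoro. What would bring this series to a measurable value stays open: the limit of > 30000 nM in this assay, at which 4 of the 4 values shown sit.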